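The source may hold more compounds than are shown below. What is called first, only, known or untested is meant among the compounds shown, and "the series" means these compounds.

Compound 3 `N#Cc1cccc(COc2ccc(-c3cc(CN4CCN(c5ccc(C(F)(F)F)cc5)CC4)no3)cc2)c1` was measured in a functional assay on Huh-7 cells (Homo sapiens) for antiproliferative activity, read by sulforhodamine B assay, with a stated time of 72 h (a lower number here means a stronger inhibitor, a higher number a weaker inhibitor), and gives 2200 nM. Among the three compounds measured so far it holds the highest number: compound 2 `Fc1ccc(COc2ccc(-c3cc(CN4CCN(Cc5ccc(C(F)(F)F)cc5)CC4)no3)cc2)cc1` gives 2000 nM, a difference within the scatter of this assay, while compound 1 `FC(F)(F)c1ccc(CN2CCN(Cc3cc(-c4ccc(OCc5cccc(Cl)c5)cc4)on3)CC2)cc1` gives 200 nM, a clearly lower number. Within the data shown here, the one single-point step that exists, a 10-fold higher number from compound 1 to compound 2 (1.00 log units; beyond the scatter), concerns a different part of the molecule from the change now considered.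

Compound 4 `N#Cc1cccc(COc2ccc(-c3cc(CN4CCN(Cc5ccc(F)cc5)CC4)no3)cc2)c1` differs from compound 3 in this way: 4-fluorobenzyl in place of 4-(trifluoromethyl)phenyl on an amine nitrogen in a ring. Among the measured compounds shown here, no measured pair differs only at this nitrogen, so the step from compound 1 to compound 2 does not speak to it directly; compound 1 and compound 2 both carry a 4-(trifluoromethyl)benzyl on that nitrogen, and compound 3 a 4-(trifluoromethyl)phenyl, but the rest of their structures also differ. Compound 4 combines the 3-cyanobenzyloxy side of compound 3 with a benzyl group on the ring nitrogen, as compound 1 and compound 2 have.

For the measured compounds named here, with no step bearing on this change, the expected step of a 1.1-fold lower number from compound 3 to compound 4 (0.04 log units; within the scatter) is taken as none beyond the scatter, with wide uncertainty in both directions. Compound 4 is therefore expected to give about 2000 nM in this assay, within a range of 500 nM to 8000 nM.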

Compound 4, half-maximal inhibitory concentration: 1600 nM
For compound 4 the middle estimate is 1.3-fold (0.10 log units) above the measured one; the range from low to high includes it.
By their numbers in this assay, from the lowest: compound 1; then compounds 4, 2 and 3 (each within the scatter of the next).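

In this assay the change on the amine nitrogen in the ring, read with the rest of the molecule held the same, gives a step within the scatter (a 1.4-fold lower number from compound 3 to compound 4 (0.14 log units; within the scatter)), so on this background 4-fluorobenzyl and 4-(trifluoromethyl)phenyl cannot be told apart. Among these compounds, this is the first reading at this place, and it contrasts with the only earlier step, which concerns a different part of the molecule and lies beyond the scatter (a 10-fold higher number from compound 1 to compound 2 (1.00 log units; beyond the scatter)). Nothing measured here bears on why the swap leaves the number within the scatter.

The step joins two differences, a benzyl in place of a phenyl and fluorine in place of trifluoromethyl on the aromatic ring, and the compounds shown do not separate them, so each alone could matter more than the pair does together. Going by these compounds, it also stays open whether the same holds with the 3-chlorophenyl group of compound 1 on the other side of the molecule, and how a phenethyl chain, a cyclohexylmethyl group or an acyl group would read on this nitrogen.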